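Cytotoxicity notes: propyl to 1-phenylethyl on the amine

The source may hold more compounds than are shown below. What is called first, only, known or untested is meant among the compounds shown, and "the series" means these compounds.

Measured compounds:
- compound 1 `CCCNCc1cc2c(cc(C(=O)N3CCC(C(=O)NCCC)CC3)n2Cc2ccc(OC)cc2)s1`: > 100000 nM in an ADME assay on HEK-293T cells (Homo sapiens) for cytotoxicity, read by luminescence, with a stated time of 24 h (a higher number here means that more compound is tolerated, a lower number that less compound is tolerated), a limit of the assay
- compound 2 `CCCNC(=O)C1CCN(C(=O)c2cc3sc(CNC(C)c4ccccc4)cc3n2Cc2ccc(OC)cc2)CC1`: 33900 nM in this assay
- compound 3 `CCCNCc1c(C(=O)N2CCC(C(=O)NCCC)CC2)n(Cc2ccc(OC)cc2)c2ccsc12`: > 100000 nM in this assay, again a limit of the assay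

The change 1-phenylethyl in place of propyl on an amine nitrogen gave an at least 2.9-fold lower number from compound 1 to compound 2 (0.46 log units; beyond the scatter). The same change 1-phenylethyl in place of propyl on an amine nitrogen leads from compound 3 to the unmeasured compound 4 `CCCNC(=O)C1CCN(C(=O)c2c(CNC(C)c3ccccc3)c3sccc3n2Cc2ccc(OC)cc2)CC1`; the place is the same in both pairs. Compounds 1 and 3 share the same atoms joined differently, but how the two cores differ is not broken down here. Compound 3 sits at the limit of > 100000 nM in this assay, at which 2 of the 3 values shown sit, so only a floor is known for it, and compound 4 is expected to move by an at least 2.8-fold lower number from compound 3 to compound 4 (0.45 log units; beyond the scatter), at least as far as compound 2 fell from compound 1. For compound 4 the estimate is 35000 nM, between 12000 nM and 100000 nM.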

Compound 4, half-maximal cytotoxic concentration: 57500 nM
Compound 4: the middle estimate sits 1.6-fold (0.22 log units) below what was measured; measured number inside the range.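

In this assay, 1-phenylethyl in place of propyl on the amine nitrogen gives an at least 1.7-fold lower number from compound 3 to compound 4 (0.24 log units; that floor lies within the scatter) on the second core, and the step on the first core was also towards a lower number. Compound 3 reads > 100000 nM and that is a limit of the assay. The step on its core therefore has only a floor, so the two cores do not contradict each other, but this does not show that the size of the change carries over: the same change on two cores in this assay, an at least 2.9-fold lower number (0.46 log units; beyond the scatter) from compound 1 to compound 2 and an at least 1.7-fold lower number (0.24 log units; that floor lies within the scatter) from compound 3 to compound 4; the limit leaves it open whether they differ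

From the compounds shown here alone, the true size of each step remains open, since both start from a limit. Also open, going by these compounds, is whether benzyl, a longer chain such as butyl, or a second substituent on the same amine nitrogen would give a similar step on either core.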